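The source may report more compounds than this note shows. Statements on the series, on what has been measured and on what is new or still open speak of the compounds shown alone.

In a functional assay on CLL cells (Homo sapiens) for cytotoxicity, read by MTT assay, with a stated time of 48 h (a lower number here means that less compound is needed, a higher number that more compound is needed for the effect), compound 3 `C=C(CC)C(=O)c1ccc(OCC(=O)Nc2ccc(/C=C/C(=O)OCC)cc2)c(Cl)c1Cl` gives 1700 nM and compound 2 `C=C(CC)C(=O)c1ccc(OCC(=O)Nc2ccc(/C=C/C(=O)NO)cc2)c(Cl)c1Cl` gives 2600 nM. Between them lies a 1.5-fold lower number from compound 2 to compound 3 (0.18 log units; within the scatter), so the two stand level. Compound 1 `C=C(CC)C(=O)c1ccc(OCC(=O)Nc2ccc(S(=O)(=O)O)cc2)c(Cl)c1Cl` is reported only as a limit of the assay, > 25000 nM. The measured changes away from its sulfo group are an at least 9.6-fold lower number from compound 1 to compound 2 (0.98 log units; beyond the scatter) and an at least 14-fold lower number from compound 1 to compound 3 (1.16 log units; beyond the scatter), both beyond the scatter. Compound 4 `C=C(CC)C(=O)c1ccc(OCC(=O)Nc2ccc(CC(=O)O)cc2)c(Cl)c1Cl` differs from compound 3 as follows: carboxymethyl in place of 2-(ethoxycarbonyl)ethenyl on an aromatic carbon. It keeps neither ethenyl group, and the steps from compound 1 are the nearest guide, though they do not measure this change. A move back towards compound 1 is therefore expected in this assay, with a higher number. The expected change is a 5.9-fold higher number from compound 3 to compound 4 (0.77 log units; beyond the scatter). Compound 4 is estimated at 10000 nM, within an expected range from 3000 nM to 25000 nM.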

Compound 4, half-maximal effective concentration: 3200 nM
The estimate for compound 4 lay 3.1-fold (0.49 log units) above the measured number, within the range that was stated.
By their numbers in this assay, from the lowest: compounds 3, 2 and 4 (each within the scatter of the next). At a limit, above all of these: compound 1.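

In this assay, carboxymethyl on this aromatic carbon, para to a large group, stands level with both ethenyl-bearing compounds, with a 1.9-fold higher number from compound 3 to compound 4 (0.27 log units; within the scatter) and a 1.2-fold higher number from compound 2 to compound 4 (0.09 log units; within the scatter) both within the scatter. Among these compounds, then, an ethenyl group is not required at this position for a number in this range. Compound 4 also separates from the sulfo compound, with an at least 7.8-fold lower number from compound 1 to compound 4 (0.89 log units; beyond the scatter) as a bound, since compound 1 stands only at a limit: the limit of > 25000 nM in this assay, at which 1 of the 4 values shown sits. On these data alone, how an amine or a longer chain ending in a carboxylic acid would read at this position remains open.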